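Hydrazone Aryl Swap in a Glioblastoma Cytotoxicity Series

The compounds below may be only part of what the source reports. "The series", "measured", "known", "first", "only" and "open" are said of these compounds alone.

Compound 1 `CN(C)CCn1cnnc1-c1cc(Oc2ccc(NC(=O)N/N=C/c3cccc(O)c3)cc2F)ccn1`: in a functional assay on U-87MG ATCC cells (Homo sapiens) for cytotoxicity, read by MTT assay, with a stated time of 72 h (a higher number here means a weaker inhibitor, a lower number a stronger inhibitor), compound 1 reaches only a limit, > 100000 nM.
Compound 2 `CN(C)CCn1cnnc1-c1cc(Oc2ccc(NC(=O)N/N=C/c3cccc(Cl)c3Cl)cc2F)ccn1`: in this assay compound 2 gives 13200 nM.
Compound 3 `CN(C)CCn1cnnc1-c1cc(Oc2ccc(NC(=O)N/N=C/c3c[nH]c4ccccc34)cc2F)ccn1`: in this assay compound 3 gives 690 nM.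

Compound 2 holds the highest of the two numbers; its nearest neighbour is reached by a 19-fold lower number from compound 2 to compound 3 (1.28 log units; beyond the scatter). Compound 4 `CN(C)CCn1cnnc1-c1cc(Oc2ccc(NC(=O)N/N=C/c3ccc(F)cc3)cc2F)ccn1` differs from compound 2 only by 4-fluorophenyl in place of 2,3-dichlorophenyl on a carbon with a double bond to nitrogen. All three measured steps change the same group on that carbon: an at least 7.5-fold lower number from compound 1 to compound 2 (0.87 log units; beyond the scatter), an at least 140-fold lower number from compound 1 to compound 3 (2.16 log units; beyond the scatter) and a 19-fold lower number from compound 2 to compound 3 (1.28 log units; beyond the scatter), each beyond the scatter. None of them involves a 4-fluorophenyl, so no direct parallel exists. Compound 4 is therefore expected to stay close to compound 2, with a 1.5-fold higher number from compound 2 to compound 4 (0.18 log units; within the scatter) falling within the scatter. The estimate for compound 4 is 20000 nM, with a range from 5000 nM to 80000 nM.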

Compound 4, half-maximal inhibitory concentration: 2310 nM
Compound 4: the middle estimate sits 8.7-fold (0.94 log units) above what was measured; the whole stated range lies above it.
By their numbers in this assay, from the lowest: compound 3; then compound 4; then compound 2. At a limit, above all of these: compound 1.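

At the carbon with a double bond to nitrogen, two halogen-carrying phenyl groups are clearly told apart: this assay shows a 5.7-fold lower number from compound 2 to compound 4 (0.76 log units; beyond the scatter). The 1H-indol-3-yl group still holds the lowest number, with a 3.3-fold higher number from compound 3 to compound 4 (0.52 log units; beyond the scatter). The 3-hydroxyphenyl group of compound 1 gives an at least 43-fold lower number from compound 1 to compound 4 (1.63 log units; beyond the scatter), and this step rests on a limit, not a number: the limit of > 100000 nM in this assay, at which 1 of the 4 values shown sits.

The compounds shown leave open how a plain phenyl or a 4-chlorophenyl group would read at this carbon. They also leave open whether a 4-aminophenyl group would behave like the 3-hydroxyphenyl group.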